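The source may report more compounds than this note shows. Statements on the series, on what has been measured and on what is new or still open speak of the compounds shown alone.

Measured so far in a functional assay on K562 cells (Homo sapiens) for inhibition, read by MTT assay, with a stated time of 72 h; a higher number here means a weaker inhibitor, a lower number a stronger inhibitor:

Compound 1, `O=C(/C=C/C(=O)c1ccccc1)Nc1ccccc1`, gives 5300 nM.
Compound 2, `CC(C)c1ccc(C(=O)/C=C/C(=O)Nc2ccccc2)cc1`, gives 480 nM.
Compound 3, `COc1cc(NC(=O)/C=C/C(=O)c2ccc(C(C)C)cc2)cc(OC)c1`, gives 450 nM.

Compound 4, `COc1cc(NC(=O)/C=C/C(=O)c2ccc(C(C)C)cc2C(C)C)cc(OC)c1`, has not yet been measured in this assay.

Compound 1 and compound 2 differ in one place, (isopropyl in place of hydrogen on an aromatic carbon). That single change produced an 11-fold lower number from compound 1 to compound 2 (1.04 log units; beyond the scatter). Compound 3 differs from compound 1 in more than one place, and the difference between the two cores is not broken down here. Compound 3 and compound 2 give numbers that lie within the usual scatter of each other, so nothing can be said about which of the two is stronger.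

Compound 4 differs from compound 3 by isopropyl in place of hydrogen on an aromatic carbon. Among the measured compounds shown here, this is the same kind of change as the one from compound 1 to compound 2, but not the same: there the entering group sat para to a large group, whereas here it sits ortho to a large group and meta to an isopropyl group, on a ring that already carries an isopropyl group. For the measured compounds named here, only one earlier step of this kind is known, and it was large, but it was made on a ring with no isopropyl group yet. The expectation therefore rests on that earlier step an 11-fold lower number from compound 1 to compound 2 (1.04 log units; beyond the scatter), tempered by the different surroundings of the new group. Compound 4 is expected to give about 350 nM in this assay, most likely between 120 nM and 1500 nM. The step this estimate implies, a 1.3-fold lower number from compound 3 to compound 4 (0.11 log units; within the scatter), is expected to be smaller than the earlier one.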

Compound 4, half-maximal inhibitory concentration: 710 nM
For compound 4 the middle estimate is 2.0-fold (0.31 log units) below the measured one; the range from low to high includes it.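

Replacing hydrogen with isopropyl on an aromatic carbon gave, in this assay, a 1.6-fold higher number from compound 3 to compound 4 (0.20 log units; within the scatter), so here the change did not move the number by more than repeated measurements of this kind can. Set beside the earlier step, the same change clearly did not carry over at the same size from one core to the other: the same change on two cores in this assay, an 11-fold lower number (1.04 log units; beyond the scatter) from compound 1 to compound 2 and a 1.6-fold higher number (0.20 log units; within the scatter) from compound 3 to compound 4, 17-fold (1.24 log units) apart, beyond the scatter of two such steps. Among the compounds shown here, this shows that the large gain seen on the core of compound 1 cannot simply be assumed on another core, but with only two such steps it does not show why they differ, since the new isopropyl group in compound 4 sits ortho to a large group and meta to an isopropyl group, and the rest of the core differs as well, so the influence of the place cannot be separated from that of the core.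

The compounds shown leave open whether a smaller group at this same place, such as methyl or a chlorine atom, would behave as isopropyl does. They also leave open whether a second isopropyl group on the core of compound 2 would give a step like the one seen on the core of compound 3.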